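Mirror-Image Configuration at the Chain Stereocentre

A few compounds are considered here, and "the series" means these few. Any claim that something is new, unique, unknown or untested is made for them only; others in the source may bear on it.

Compound 1 `O[C@H](COc1ccc(C(F)(F)F)cc1)CN1CCN(c2ccccc2F)CC1`: 48.9%
Compound 2 `O[C@H](COc1ccc(Cl)cc1)CN1CCN(c2ccccc2F)CC1`: 35.9%

In an assay on HEK293 cells for inhibition of Voltage-dependent T-type calcium channel subunit alpha-1G (Homo sapiens), read by patch clamp, tested at 10 uM (on this read-out lower numbers stand for less inhibition and higher numbers for more inhibition at the one concentration tested (going by the name of the read-out)), compound 1 gives 48.9%, while compound 2 gives 35.9%, the lower of the two numbers. Among the measured compounds shown here, the only measured step, a number 13 percentage points lower from compound 1 to compound 2 (beyond the scatter), concerns an aromatic substituent. Compound 3 `O[C@@H](COc1ccc(Cl)cc1)CN1CCN(c2ccccc2F)CC1` differs from compound 2 as follows: the two compounds have the same atoms and bonds and differ only in configuration as drawn: 1 of 1 stereo elements differ; a stereocentre at a saturated chain carbon is drawn S in compound 2 and R in compound 3. For the measured compounds named here, no measured step involves a change of configuration, so the one known step does not bear on this change, and the data give no direction. Compound 3 is expected to stay close to its mirror image, with an estimated change of a number 0.1 percentage points higher from compound 2 to compound 3 (within the scatter). Compound 3 is estimated at 36%, within a wide range from 15% to 58%.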

Compound 3, a percentage reported as inhibition, at one concentration (the size of the read-out at that concentration, not a potency): 46.9%
For compound 3 the middle estimate is 10.9 percentage points below the measured one, and the stated range covers the measured number.
By their numbers in this assay, from the lowest: compound 2; then compounds 3 and 1 (each within the scatter of the next).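

The configuration at the saturated chain carbon is not silent in this assay, which shows a number 11 percentage points higher from compound 2 to compound 3 (beyond the scatter). The earlier step concerned only an aromatic substituent, whereas this one shows that the stereocentre alone can shift the number. The shift can be assigned to that centre because nothing else changes: the fact that compounds 2 and 3 differ only in the configuration as drawn

The compounds shown leave open whether the mirror image of compound 1 would shift in the same direction. They also leave open how an amine in place of the hydroxyl would behave in either configuration.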